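Isopropyl to fluoro on the aryl urea of compound 1

A few compounds are considered here, and "the series" means these few. Any claim that something is new, unique, unknown or untested is made for them only; others in the source may bear on it.

Measured compounds:
- compound 1, `CC(C)c1ccccc1NC(=O)N[C@H](C)c1ccccc1`: 103%
- compound 2, `CC(C)c1ccccc1NC(=O)N[C@@H](C)c1ccccc1`: 99%
- compound 3, `CC(=O)c1cccc(NC(=O)N[C@@H](C)c2ccccc2)c1`: 96%

Three ureas have been tested in an ADME assay on the whole organism with Oryza sativa as the target, tested at 0.1 uM; on this read-out lower numbers stand for a stronger effect and higher numbers for a weaker effect at the one concentration tested. Compound 1 gives 103% in this assay, the highest of the three numbers; compound 2 sits nearest with 99%, and compound 3 is furthest away with 96%. All three lie within the scatter of one another, so none can be set apart from the others.

Among the compounds with values here, the only step between two compounds that differ in one place is a number 4 percentage points lower from compound 1 to compound 2 (within the scatter); it rests on the fact that compounds 1 and 2 differ only in the configuration as drawn and changes nothing beyond the scatter.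

Compound 4, `C[C@@H](NC(=O)Nc1ccccc1F)c1ccccc1`, is not yet measured. It differs from compound 1 by fluoro in place of isopropyl on an aromatic carbon. Within the data shown here, no measured step involves a change of this kind, so the measured steps give no direct guide to its size or direction. Among the measured compounds shown here, what the three measured compounds do show is that every number so far sits near the top of the scale and that the one measured step stays inside the scatter. On that basis compound 4 is expected to give 98% in this assay, with a range from 85% to 110%. The step that this estimate means is a number 5 percentage points lower from compound 1 to compound 4 (within the scatter), and it is expected to stay within the scatter.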

Compound 4, a percentage reported as activity, at one concentration (the size of the read-out at that concentration, not a potency): 97%
Compound 4: the middle estimate sits 1 percentage points above what was measured; the measured number falls inside the stated range.
By their numbers in this assay, from the lowest: compounds 3, 4, 2 and 1 (each within the scatter of the next).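

In this assay, replacing isopropyl, with its 3 heavy atoms, by fluoro, with 1 heavy atom, on this aromatic carbon ortho to a large group gives a number 6 percentage points lower from compound 1 to compound 4 (within the scatter). Within the data shown here, the earlier step altered only the configuration as drawn, whereas this is the first step to replace a group on the aromatic ring, and it too does not separate the two compounds, so this position tolerates this particular exchange without a change that can be told from the scatter. The data shown offer no explanation for why the read-out stays within the scatter across this exchange.

From the compounds shown here alone, what remains open is whether a different kind of group at this position, such as an amine, a carboxylic acid or a longer chain, would give a step beyond the scatter, or whether this position simply has little bearing on the read-out. Going by these compounds, it is also open whether the fluoro compound drawn with the opposite configuration would stay within the scatter of compound 4, as compound 2 does of compound 1.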